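The source may report more compounds than this note shows. Statements on the series, on what has been measured and on what is new or still open speak of the compounds shown alone.

Measured in a toxicity assay on THP-1 cells (Homo sapiens) for inhibition; a higher number here means that more compound is tolerated, a lower number that less compound is tolerated:
- Compound 1 `CCCC(=O)Nc1ncc(-c2ccc(OC)cc2)n1C` gives > 100000 nM (a limit)
- Compound 2 `Cn1c(-c2ccccc2Cl)cnc1NC(=O)c1ncc[nH]1` gives > 50000 nM (a limit)
- Compound 3 `Cn1c(-c2ccccc2Cl)cnc1NC(=O)c1ccc(F)cc1` gives > 50000 nM (a limit)

None of the three results is a number. Compound 3 stands at > 50000 nM as a limit of the assay, and it shares that position with compound 2, as the limit of > 50000 nM in this assay, at which 2 of the 3 values shown sit, records. Compound 4 `Cn1c(-c2ccc(F)cc2)cnc1NC(=O)c1ccc(F)cc1` has 4-fluorophenyl in place of 2-chlorophenyl on an aromatic carbon and keeps everything else from compound 3.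

Among the compounds with values here, the only measured step that bears on this is a step that the two limits leave unreadable from compound 2 to compound 3, and it lies on a carbonyl carbon, not on the aromatic carbon that changes here. It therefore gives no size to carry over, and no direction. With nothing in the data pointing to a shift, no step beyond the scatter is expected in this assay, and compound 4 is expected to remain close to the limit of compound 3. The expected step is a step that the limit leaves unreadable from compound 3 to compound 4 in this estimate. Compound 4 is estimated at 60000 nM, with an expected range of 25000 nM to 100000 nM.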

Compound 4, half-maximal cytotoxic concentration: > 100000 nM
Compound 4: only a limit was reported (the forecaster's own chance of this, stated with the estimate: 85%); middle value at least 1.6-fold (0.22 log units) away from the limit.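

In this assay compound 3 gives > 50000 nM, which is a limit. Compound 4 gives > 100000 nM, also a limit, so no step can be read between compound 3 and compound 4. The compounds shown leave open what concentration of any of them is half-maximally cytotoxic, and whether 4-fluorophenyl in place of 2-chlorophenyl changes it.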